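Working notes on compound 4 and its measured neighbours

A few compounds are considered here, and "the series" means these few. Any claim that something is new, unique, unknown or untested is made for them only; others in the source may bear on it.

Measured so far:
compound 1, `O=C(NCCNS(=O)(=O)c1ccc(-c2ccccc2Oc2ccc([N+](=O)[O-])c([N+](=O)[O-])c2)s1)Nc1cc(Cl)cc(Cl)c1`, > 20000 nM
compound 2, `Cc1ccc(-c2ccsc2S(=O)(=O)NCCNC(=S)Nc2ccc([N+](=O)[O-])cc2)c(Oc2ccc(O)c(O)c2)c1`, 8200 nM
compound 3, `O=C(Nc1ccc([N+](=O)[O-])cc1)N1CCN(S(=O)(=O)c2sccc2-c2ccccc2Oc2ccc(O)c(O)c2)CC1`, > 20000 nM

In an ADME assay on HEK-293T cells (Homo sapiens) for cytotoxicity, read by CCK-8 assay, with a stated time of 48 h (a lower number here means a stronger inhibitor, a higher number a weaker inhibitor), compound 1 returns only a limit, > 20000 nM. Compound 3 likewise returns a limit, > 20000 nM. Among the measured compounds shown here, compound 2 gives 8200 nM, the only numerical value in this assay so far. Compound 4, `COc1ccc(NC(=O)NCCNS(=O)(=O)c2sccc2-c2ccc(C)cc2Oc2ccc(O)c(O)c2)cc1`, has not yet been measured. It differs from compound 2 as follows: a group of 11 heavy atoms (8 carbon, 1 nitrogen, 2 oxygen; one six-membered aromatic ring of carbon only) in place of a group of 12 heavy atoms (7 carbon, 2 nitrogen, 2 oxygen, 1 sulfur; one six-membered aromatic ring of carbon only), on an amine nitrogen. For the measured compounds named here, no step between measured compounds is available, so no direction is backed by a measured pair. Compound 1 and compound 3 both sit at the limit of > 20000 nM in this assay, at which 2 of the 3 values shown sit. The step is therefore expected to weaken inhibition: a 1.8-fold higher number from compound 2 to compound 4 (0.26 log units; within the scatter). The estimate for compound 4 in this assay is 15000 nM, between 5000 nM and 45000 nM, with a fair chance that only a limit is returned.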

Compound 4, half-maximal inhibitory concentration: > 20000 nM
Compound 4 gave a limit, no number (the forecaster's own chance of this, stated with the estimate: 45%); middle value at least 1.3-fold (0.12 log units) from the limit.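

Among the compounds shown here, on the amine nitrogen, (4-methoxyphenyl)carbamoyl in place of the group of 12 heavy atoms gives an at least 2.4-fold higher number from compound 2 to compound 4 (0.38 log units; beyond the scatter) in this assay, the first step that can be read, and its size is only a floor. Compound 4 returns only a limit, > 20000 nM. Of the compounds shown, only compound 2 now gives a number: the limit of > 20000 nM in this assay, at which 3 of the 4 values shown sit.

From the compounds shown here alone, how far the step really reaches stays open. The compounds shown also do not tell whether a free amine or a carboxylic acid on that nitrogen would return a number.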